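Compound 3 to compound 4: tert-butyl to methyl

The source may report more compounds than this note shows. Statements on the series, on what has been measured and on what is new or still open speak of the compounds shown alone.

Values in a functional assay on MDA-MB-231 cells (Homo sapiens) for inhibition, read by microscopy and colony formation, with a stated time of 10 days; on this read-out lower numbers stand for stronger inhibition and higher numbers for weaker inhibition:
- compound 1 `CCCCCCCCCCCCCCNC(=O)[C@H](CO)NC(=O)C1CCCCC1`: 11500 nM
- compound 2 `CCCCCCCCCCCCCCNC(=O)[C@H](CO)/N=C/c1ccccc1`: 2400 nM
- compound 3 `CCCCCCCCCCCCCCNC(=O)[C@H](CO)NC(=O)C(C)(C)C`: 6100 nM

The position of compound 3 at 6100 nM is defined by two steps. The nearer is a 1.9-fold lower number from compound 1 to compound 3 (0.28 log units; within the scatter), and the further is a 2.5-fold higher number from compound 2 to compound 3 (0.41 log units; beyond the scatter).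

Compound 4 `CCCCCCCCCCCCCCNC(=O)[C@H](CO)NC(C)=O` is the next case, with the difference methyl in place of tert-butyl on a carbonyl carbon. For the measured compounds named here, the only measured step at that same place is a 1.9-fold lower number from compound 1 to compound 3 (0.28 log units; within the scatter), and it stays within the scatter. The other two, a 4.8-fold lower number from compound 1 to compound 2 (0.68 log units; beyond the scatter) and a 2.5-fold higher number from compound 2 to compound 3 (0.41 log units; beyond the scatter), exchange a larger group on a saturated chain carbon and bear on this change only loosely. Going by these compounds, three compounds give no firm trend for the group on the carbonyl carbon, so no step beyond the scatter is expected in this assay, and the direction stays open. The expected change is a 1.1-fold lower number from compound 3 to compound 4 (0.04 log units; within the scatter). Compound 4 is estimated at 5500 nM, with an expected range of 2400 nM to 13000 nM.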

Compound 4, half-maximal inhibitory concentration: 75100 nM
Estimate against measurement, compound 4: 14-fold (1.14 log units) below; measured number outside the range, above it.
By their numbers in this assay, from the lowest: compound 2; then compounds 3 and 1 (each within the scatter of the next); then compound 4.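

In this assay the group on the carbonyl carbon proves not to be a free exchange: methyl in place of tert-butyl gives a 12-fold higher number from compound 3 to compound 4 (1.09 log units; beyond the scatter) whereas the earlier step from cyclohexyl to tert-butyl stayed within the scatter. Methyl in place of cyclohexyl runs the same way with a 6.5-fold higher number from compound 1 to compound 4 (0.81 log units; beyond the scatter) and acetamido in place of the group holding the aromatic ring gives a 31-fold higher number from compound 2 to compound 4 (1.50 log units; beyond the scatter) so the number for compound 4 stands beyond the scatter from all three others, as the weakest of the four. No evidence at hand accounts for this loss.

The compounds shown leave open where the number starts to rise between methyl and tert-butyl, a question that ethyl or isopropyl on the carbonyl carbon would address. They also leave open whether a small group of another kind at this place, such as an amine or a carboxylic acid, behaves like methyl.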